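Swapping the Aryl Substituent in a Spiro Hydantoin Series

This account rests on a few compounds, and the source may have more. Where it says the series, first, only, none or still open, it means among the compounds named here.

Measured so far:
Compound 1 `Cc1cccc(C(=O)NN2C(=O)NC3(CC3(C)C)C2=O)c1` gives 100 mg/kg in a functional assay on the whole organism (Hindlimb) for inhibition, with Mus musculus as the target, with a stated time of 0.5 h; a higher number here means that more compound is needed for the effect, a lower number that less compound is needed.
Compound 2 `CC1(C)CC12NC(=O)N(NC(=O)c1ccc(Cl)cc1)C2=O` gives 100 mg/kg in this assay.

Compound 2 stands level with compound 1: the step of no change at the digits printed from compound 1 to compound 2 (within the scatter) shows that exchanging the group on the carbonyl carbon made no difference beyond the scatter. Compound 3 `COc1ccc(C(=O)NN2C(=O)NC3(CC3(C)C)C2=O)cc1` is the next member of the series; it has not yet been tested in this assay. Its change from compound 2 is methoxy in place of chloro on an aromatic carbon. Within the data shown here, only one measured step bears on this, the step from compound 1 to compound 2, which was flat. The shared core is kept, and a change on the aromatic ring has so far left the minimum effective dose where it was, so no step beyond the scatter is expected here either. For compound 3 the expected step is no change at the digits printed from compound 2 to compound 3 (within the scatter), giving an estimate of 100 mg/kg with a range from 50 mg/kg to 200 mg/kg.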

Compound 3, minimum effective dose: 100 mg/kg
The estimate for compound 3 equals the measured number at the digits printed; measured number inside the range.
By their numbers in this assay, from the lowest: compounds 1, 2 and 3 (each within the scatter of the next).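

The result, no change at the digits printed from compound 2 to compound 3 (within the scatter), isolates a single position, on an aromatic carbon para to a large group, where the earlier step had changed the substituent and its place on the ring together. In this assay, this position accepts either chloro or methoxy without a shift beyond the scatter, even though methoxy is the larger group by heavy atoms and brings a hydrogen-bond acceptor that chloro lacks. No measurement available here explains why the minimum effective dose holds across this change.

Going by these compounds, it remains open whether an amine or a carboxylic acid at this same place on the ring would move the dose. Also open, on these data alone, is whether changes to the shared core, rather than to the aromatic ring, would alter it.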